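Swapping Bromine for Chlorine on Two Different Cores

A few compounds are considered here, and "the series" means these few. Any claim that something is new, unique, unknown or untested is made for them only; others in the source may bear on it.

Compound 1, `Cc1ccc(C(=O)/C=C/c2cc(Cl)ccc2O)cc1`: 27.7%
Compound 2, `Cc1ccc(C(=O)/C=C/c2cc(Br)ccc2O)cc1`: 31.8%
Compound 3, `COC(=O)C1=C(N)Oc2ccc(Br)cc2C1CC(=O)c1ccccc1`: 41.3%

All three values come from a functional assay on MCF7 cells (Homo sapiens) for antiproliferative activity, read by sulforhodamine B assay, with a stated time of 72 h, tested at 30 uM; a higher number here means a weaker effect of the compound at the concentration tested, a lower number a stronger effect. Compound 4, `COC(=O)C1=C(N)Oc2ccc(Cl)cc2C1CC(=O)c1ccccc1`, is still to be measured. Compound 1 and compound 2 share one core, compound 3 and compound 4 another; the difference between the two cores is not broken down here. Within the first core the change is chloro in place of bromo on an aromatic carbon and it produced a number 4.1 percentage points lower from compound 2 to compound 1 (within the scatter). The change leading to compound 4 is chloro in place of bromo on an aromatic carbon, the same kind of change, though its surroundings differ: in compound 3 the ring is part of a fused or bridged system of two rings, with the halogen meta to a fused ring and para to a fused ring, whereas in compound 2 the halogen sits meta to a large group and para to a hydroxy group. Compound 3 gave the highest number of the three, though its gap to compound 2 is within the scatter, and only its gap to compound 1 is beyond it.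

For compound 4 the expected step is a number 4.3 percentage points lower from compound 3 to compound 4 (within the scatter), because the matching change gave a number 4.1 percentage points lower from compound 2 to compound 1 (within the scatter). Compound 4 is therefore estimated at 37%, expected to fall between 26% and 48%.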

Compound 4, a percentage reported as activity, at one concentration (the size of the read-out at that concentration, not a potency): 44.2%
The estimate for compound 4 lay 7.2 percentage points below the measured number; the measured number falls inside the stated range.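

In this assay, putting chloro in place of bromo on the core of compound 3 gave a number 2.9 percentage points higher from compound 3 to compound 4 (within the scatter), so the two compounds cannot be told apart in this read-out. Set beside the same swap on the core of compound 1, the two cores give no sign of responding differently: the same change on two cores in this assay, a number 4.1 percentage points lower (within the scatter) from compound 2 to compound 1 and a number 2.9 percentage points higher (within the scatter) from compound 3 to compound 4, 7 percentage points apart, within the scatter of two such steps This shows only that the step was small on both cores; it does not show that the two steps are truly equal or that their opposite directions mean anything, and such small steps say little about whether a larger effect would carry from one core to the other.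

The compounds shown carry only these two halogens at this place, so it remains open how a fluoro group, a methyl group or an amine there would read out in this assay. Also open, going by these compounds, is whether a carboxylic acid in place of the methyl ester of compound 3 or compound 4 would shift the number.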